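The source may hold more compounds than are shown below. What is called first, only, known or untested is meant among the compounds shown, and "the series" means these compounds.

Of the compounds shown here, three of one family have been measured in a functional assay on A549 cells (Homo sapiens) for cytotoxicity, read by WST assay, with a stated time of 48 h (a lower number here means a stronger inhibitor, a higher number a weaker inhibitor), all built on a shared core. Compound 1, `N#C/C(=C\c1cn(Cc2ccc(Cl)cc2)c2ccccc12)C(=O)c1c[nH]c2ccccc12`, carries a chlorobenzyl group on its core. In this assay compound 1 reaches only the limit of the measurement, giving > 50000 nM, which is a limit and not a number. Compound 3, `COc1ccc2[nH]cc(/C=C(\C#N)C(=O)c3c[nH]c4ccccc34)c2c1`, carries a methoxy group on the core and no benzyl group; in this assay compound 3 gives 13700 nM. Compound 2, `COc1ccc(Cn2cc(/C=C(\C#N)C(=O)c3c[nH]c4cc(OC)ccc34)c3ccccc32)cc1`, carries both a methoxybenzyl group and a methoxy group on the core; in this assay compound 2 gives 28900 nM, the highest of the two plain numbers, the nearest being compound 3 with its lower number.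

Compound 4, `COc1ccc2c(C(=O)/C(C#N)=C/c3cn(Cc4ccc(Cl)cc4)c4ccccc34)c[nH]c2c1`, has not yet been measured. It differs from compound 2 in one place: chloro in place of methoxy on an aromatic carbon. Going by the values given here, no measured pair shows this exact change, so its size is not known from these data. Compound 1, which also carries a chlorobenzyl group, gave only > 50000 nM, a limit, so compound 4 is expected to give a weaker result than compound 2, with a step of a 1.5-fold higher number from compound 2 to compound 4 (0.16 log units; within the scatter). The estimate for compound 4 in this assay is 42000 nM, somewhere between 15000 nM and 120000 nM.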

Compound 4, half-maximal inhibitory concentration: > 50000 nM
Compound 4: no number, only a limit; the forecaster's own chance of this, stated with the estimate: 40%; at least 1.1-fold (0.07 log units) between middle value and limit.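

Going from 4-methoxybenzyl to 4-chlorobenzyl, with the rest of compound 2 unchanged, gives the first direct reading of this change at this position in this assay: the result is an at least 1.7-fold higher number from compound 2 to compound 4 (0.23 log units; that floor lies within the scatter). Only the smallest possible size of this step is known, and that smallest size does not by itself separate the two compounds, so the change cannot yet be given a firm size. Compound 1 and compound 4 both carry the 4-chlorobenzyl group and both stop at a limit of the assay rather than giving a number, so the step for methoxy in place of hydrogen between them cannot be read: the limit of > 50000 nM in this assay, at which 2 of the 4 values shown sit.

Still open, going by these compounds, is how large the step from 4-methoxybenzyl to 4-chlorobenzyl really is, since a limit gives only one end of it. Also open, on these data alone, is whether a quite different group at this place on the benzyl ring, such as an amine or a carboxylic acid, would give a lower number than the methoxy of compound 2.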